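The source may report more compounds than this note shows. Statements on the series, on what has been measured and on what is new or still open speak of the compounds shown alone.

Series notes. Compound 2 `N#CC1=C(N)Oc2c(c3nc4ccccc4nc3c3ccccc23)C12C(=O)N(Cc1cnnn1-c1cccc(S(N)(=O)=O)c1)c1ccccc12` carries a 3-sulfamoylphenyl group on an aromatic nitrogen; in a functional assay on HepG2 cells (Homo sapiens) for antiproliferative activity, read by MTT assay, with a stated time of 48 h (a lower number here means a stronger inhibitor, a higher number a weaker inhibitor), compound 2 gives 21500 nM. Among the compounds with values here, that is the only number obtained so far; the one other value is a limit. Compound 1 `N#CC1=C(N)Oc2c(c3nc4ccccc4nc3c3ccccc23)C12C(=O)N(Cc1cnnn1-c1ccc([N+](=O)[O-])cc1)c1ccccc12`, with 4-nitrophenyl in that place, reaches only the limit of > 50000 nM in this assay. Within the data shown here, the step of an at least 2.3-fold lower number from compound 1 to compound 2 (0.36 log units; beyond the scatter) is the single measured step, and its stated size rests on (the limit of > 50000 nM in this assay, at which 1 of the 2 values shown sits).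

Compound 3 `Cc1ccc(-n2nncc2CN2C(=O)C3(C(C#N)=C(N)Oc4c3c3nc5ccccc5nc3c3ccccc43)c3ccccc32)cc1C` differs from compound 2 by 3,4-dimethylphenyl in place of 3-sulfamoylphenyl on an aromatic nitrogen. Among the measured compounds shown here, no measured step covers this change; the only step available exchanges one substituted phenyl for another on an aromatic nitrogen, and its direction cannot simply be carried over to a third phenyl. Both measured compounds sit at weak potency, so the expectation for compound 3 is a value of the same order, with a considerable chance that this assay returns only a limit. Compound 3 is estimated at 30000 nM in this assay, with a likely range of 8000 nM to 100000 nM. The expected step of a 1.4-fold higher number from compound 2 to compound 3 (0.14 log units; within the scatter) is modest at most.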

Compound 3, half-maximal inhibitory concentration: > 50000 nM
Compound 3 was reported as a limit; the forecaster's own chance of this, stated with the estimate: 40%; middle value at least 1.6-fold (0.22 log units) away from the limit.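

With 3,4-dimethylphenyl in place of 3-sulfamoylphenyl on the aromatic nitrogen, this assay shows an at least 2.3-fold higher number from compound 2 to compound 3 (0.36 log units; beyond the scatter). This position therefore responds to a second exchange of the substituted phenyl group, and among the compounds shown, a measurable number appears only with 3-sulfamoylphenyl, while 4-nitrophenyl and 3,4-dimethylphenyl both end at a limit. No order can be read between compound 1 and compound 3, and the readable steps give only a minimum size, because the comparison rests on this: the limit of > 50000 nM in this assay, at which 2 of the 3 values shown sit.

The compounds shown leave open whether the number for compound 2, 21500 nM in this assay, goes with the sulfamoyl group itself or with any substituent of that kind on the phenyl ring, and an amine or a carboxylic acid in its place would test this. Also open is how much of the remaining difference can be resolved, since a change on this phenyl ring that gives a number well below that of compound 2 is not among the compounds shown.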